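This account rests on a few compounds, and the source may have more. Where it says the series, first, only, none or still open, it means among the compounds named here.

Measured so far:
compound 1, `COc1ccc2c(c1)c(/C=N\NC(=O)c1c[nH]c3ccccc13)cn2Cc1ccc(Cl)cc1`: > 100000 nM
compound 2, `Cn1cc(C(=O)N/N=C\c2cn(Cc3ccc(Cl)cc3)c3cc(F)ccc23)c2ccccc21`: > 100000 nM
compound 3, `COc1ccc(Cn2cc(/C=N\NC(=O)c3c[nH]c4ccccc34)c3ccc(F)cc32)cc1`: > 100000 nM

In a functional assay on LNCaP cells (Homo sapiens) for cytotoxicity (on this read-out higher numbers stand for weaker inhibition and lower numbers for stronger inhibition), compound 2 gives > 100000 nM, which is a limit of the assay and not a number. Compound 1 likewise gives only a limit, > 100000 nM. Compound 3 also gives only a limit, > 100000 nM. All three values sit at the limit of > 100000 nM in this assay, at which 3 of the 3 values shown sit, so no order among them can be read. Compound 4, `O=C(N/N=C\c1cn(Cc2ccc(Cl)cc2)c2cc(F)ccc12)c1c[nH]c2ccc(Br)cc12`, differs from compound 2 by 5-bromo-1H-indol-3-yl in place of 1-methyl-1H-indol-3-yl on a carbonyl carbon. Going by the values given here, no step between measured compounds exists here, and every value shown is a limit, so in this assay the change is expected to bring no step beyond the scatter. Compound 4 is therefore expected at 120000 nM, between 30000 nM and 500000 nM, an expected step that the limit leaves unreadable from compound 2 to compound 4.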

Compound 4, half-maximal inhibitory concentration: 24800 nM
Beside the measured number, compound 4's estimate is 4.8-fold (0.68 log units) above it; measured number below the stated range.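

In this assay, going by these compounds alone, compound 4 gives 24800 nM, the only number among the four compounds, so a change on this carbonyl carbon can bring a measurable read-out in the shared core. Placing 5-bromo-1H-indol-3-yl there in place of 1-methyl-1H-indol-3-yl gives an at least 4.0-fold lower number from compound 2 to compound 4 (0.60 log units; beyond the scatter). Compound 2 gives > 100000 nM, which is a limit of the assay and not a number, so the full size of the step cannot be read: the limit of > 100000 nM in this assay, at which 3 of the 4 values shown sit.

The change both adds the bromine and removes the methyl, and the compounds shown do not separate the two. From the compounds shown here alone, whether 5-chloro-1H-indol-3-yl or 5-amino-1H-indol-3-yl would give a similar step also remains open.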